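The source may report more compounds than this note shows. Statements on the series, on what has been measured and on what is new or still open speak of the compounds shown alone.

Three measured members of the series share one core. Compound 1 `COc1cc(/C=C/c2ccc(NC(=O)/C=C/c3ccc(F)cc3)cc2)cc(OC)c1` gives 9390 nM in a functional assay on MDA-MB-231 cells (Homo sapiens) for inhibition, read by MTT assay, with a stated time of 48 h; a lower number here means a stronger inhibitor, a higher number a weaker inhibitor. Compound 2 `COc1cc(/C=C/c2ccc(NC(=O)/C=C/c3cccc(F)c3)cc2)cc(OC)c1` gives 17300 nM in this assay. Compound 3 `COc1cc(/C=C/c2ccc(OC(=O)/C=C/c3ccccc3)cc2)cc(OC)c1` gives 9810 nM in this assay. Compound 3 thus stands second highest of the three numbers; its number and that of compound 1 lie within the scatter of each other, and its gap to compound 2 is also within the scatter, so no order among the three is established.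

The unmeasured compound 4 `COc1cc(/C=C/c2ccc(OC(=O)/C=C/c3ccc(C(F)(F)F)cc3)cc2)cc(OC)c1` differs from compound 3 in one place: trifluoromethyl in place of hydrogen on an aromatic carbon. Among the compounds with values here, the only measured step, a 1.8-fold higher number from compound 1 to compound 2 (0.27 log units; within the scatter), concerns a shift of fluorine on the same ring and falls within the scatter. No measured pair shows the trifluoromethyl group entering on this ring, and the amide and ester members shown give numbers within the scatter of each other, so nothing in the series points to a change beyond the scatter from this substitution. The step from compound 3 to compound 4 is therefore expected to be a 1.1-fold lower number from compound 3 to compound 4 (0.04 log units; within the scatter), with no direction claimed beyond the scatter.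

Compound 4 is estimated at 9000 nM in this assay, with a range from 3000 nM to 30000 nM.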

Compound 4, half-maximal inhibitory concentration: 6910 nM
Compound 4: middle estimate off by 1.3-fold (0.11 log units), on the high side; the range from low to high includes it.
By their numbers in this assay, from the lowest: compounds 4, 1, 3 and 2 (each within the scatter of the next, the first and the last beyond it).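

Trifluoromethyl in place of hydrogen on an aromatic carbon, para to a large group, gives a 1.4-fold lower number from compound 3 to compound 4 (0.15 log units; within the scatter) in this assay, and this step lies within the scatter. Unlike the earlier step between the 4-fluorophenyl and 3-fluorophenyl amides, it puts a substituent on the unsubstituted phenyl of an ester member, so this position in compound 4 is seen to carry a group of four heavy atoms with no change beyond the scatter from compound 3. Nothing measured alongside these numbers bears on the reason for this outcome.

On these data alone, the result covers a single substituent at a single position on the ester, so it remains open whether an amine, a carboxylic acid or a longer chain such as n-butyl in the same place would also stay within the scatter of compound 3. Also open, as far as these compounds go, is whether 4-(trifluoromethyl)phenyl in place of 4-fluorophenyl on the amide of compound 1 would stay within the scatter in the same way.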